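This account rests on a few compounds, and the source may have more. Where it says the series, first, only, none or still open, it means among the compounds named here.

Compound 1, `O=c1[nH]c(=O)n(C2C[C@@H](O)[C@@H](CO)O2)nc1/C=C(\F)Br`: > 500 ug/mL
Compound 2, `COC(=O)/C=C/c1nn(C2C[C@@H](O)[C@@H](CO)O2)c(=O)[nH]c1=O`: > 500 ug/mL

In a functional assay on Vero cells (Chlorocebus sabaeus) for cytotoxicity (on this read-out lower numbers stand for stronger inhibition and higher numbers for weaker inhibition), compound 1 gives > 500 ug/mL, a limit of the assay rather than a number. Compound 2 likewise gives only a limit, > 500 ug/mL, in this assay. Compound 2 thus sits at the limit of > 500 ug/mL in this assay, at which 2 of the 2 values shown sit. The step that the two limits leave unreadable from compound 1 to compound 2 is unreadable because both values are limits. Compound 3, `COC(F)(F)Cc1nn(C2C[C@@H](O)[C@@H](CO)O2)c(=O)[nH]c1=O`, differs from compound 2 by a group of 6 heavy atoms (3 carbon, 1 oxygen, 2 fluorine; no ring) in place of a group of 6 heavy atoms (4 carbon, 2 oxygen; no ring), on an aromatic carbon. Within the data shown here, no measured step bears on this change, so no step beyond the scatter is expected; the estimated step is a number no higher from compound 2 to compound 3 (the limit leaves the size open). Compound 3 is expected at 500 ug/mL, in a range from 200 ug/mL to 1000 ug/mL.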

Compound 3, concentration for 50% inhibition: > 500 ug/mL
Compound 3 ended at the assay's limit; the forecaster's own chance of this, stated with the estimate: 85%; the middle value lies on the limit itself.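

No step can be read among compound 1, compound 2 and compound 3, because all three stand at one limit of the assay, not at a number: the limit of > 500 ug/mL in this assay, at which 3 of the 3 values shown sit. From the compounds shown here alone, how far apart they truly lie in this assay, and whether changing the group on the aromatic carbon alters that read-out at all, stays open.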